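The source may hold more compounds than are shown below. What is called first, only, known or untested is meant among the compounds shown, and "the series" means these compounds.

Compound 1 `COc1ccccc1N1CCN(CCCCC(=O)NCc2ccccc2-c2cccc(F)c2)CC1` gives 34.7 nM in an assay on CHO-K1 cells for displacement of a labelled ligand from 5-hydroxytryptamine receptor 7 (Homo sapiens), read by scintillation counting; on this read-out lower numbers stand for stronger inhibition and higher numbers for weaker inhibition. Compound 2 `COc1ccccc1N1CCN(CCC(=O)NCc2ccccc2-c2ccccc2)CC1` gives 187 nM in this assay. Compound 3 `COc1ccccc1N1CCN(CCCC(=O)NCc2ccccc2-c2ccccc2)CC1` gives 64.5 nM in this assay.

Among the three measured compounds, compound 1 has the lowest inhibition constant. Its nearest neighbour is compound 3, whose number lies within the usual scatter of this assay, so the two cannot be set in order. Compound 2 stands furthest away, and its gap to compound 1 is beyond the scatter. For the measured compounds named here, no pair of measured compounds differs in a single place, so the values speak only for themselves and no single structural step can be read from them.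

Compound 4 `COc1ccccc1N1CCN(CCCCC(=O)NCc2ccccc2-c2ccccc2C)CC1` is not yet measured. It differs from compound 1 by 2-methylphenyl in place of 3-fluorophenyl on an aromatic carbon, ortho to a large group. Going by the values given here, none of the measured compounds isolates this exchange: compound 2 and compound 3 carry an unsubstituted phenyl and shorter chains, so they do not show what the change does on its own. For compound 4 the step of a 1.3-fold higher number from compound 1 to compound 4 (0.11 log units; within the scatter) in this assay is therefore expected to stay within the scatter, with no clear direction. The estimate for compound 4 is 45 nM, in a range from 15 nM to 140 nM.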

Compound 4, inhibition constant: 26.1 nM
Estimate against measurement, compound 4: 1.7-fold (0.24 log units) above, and the stated range covers the measured number.
By their numbers in this assay, from the lowest: compounds 4, 1 and 3 (each within the scatter of the next, the first and the last beyond it); then compound 2.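

In this assay, putting 2-methylphenyl in place of 3-fluorophenyl on an aromatic carbon, ortho to a large group, gives a 1.3-fold lower number from compound 1 to compound 4 (0.12 log units; within the scatter), so compound 1 and compound 4 cannot be set in order. This is the first pair shown that differs in one place, and it shows that, with the chain and the rest of the core of compound 1 held fixed, this exchange produces no change that can be told from the scatter. No measurement shown here explains this outcome.

As far as these compounds go, the step exchanges one whole substituted phenyl for another, so it cannot separate the effect of methyl from that of fluorine, or the effect of one place on the ring from another, and whether the same exchange would behave alike on the shorter chains of compound 2 and compound 3 also stays open. Nor do the compounds shown say how the number would respond to a different group at this position, such as a nitrile, a trifluoromethyl, an amine or a carboxylic acid on the phenyl ring.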